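The compounds below may be only part of what the source reports. "The series", "measured", "known", "first", "only" and "open" are said of these compounds alone.

Compound 1 `CCCCN1CCc2nc(C#Cc3ccccc3)sc2C1`: 110 nM
Compound 2 `CC1CC(C(=O)N2CCc3nc(C#Cc4ccccc4)sc3C2)C1`: 81 nM
Compound 3 `O=C(C1CC(F)C1)N1CCc2nc(C#Cc3ccccc3)sc2C1`: 85 nM

In an assay on HEK293 cells for positive allosteric modulation of metabotropic glutamate receptor 5 (Homo sapiens), read by FLIPR, with a stated time of 1 h (on this read-out higher numbers stand for an effect only at larger amounts of compound and lower numbers for an effect already at smaller amounts), compound 3 gives 85 nM, and it sits alongside the other two: a 1.3-fold lower number from compound 1 to compound 3 (0.11 log units; within the scatter) and a 1.0-fold higher number from compound 2 to compound 3 (0.02 log units; within the scatter). Compound 4 `O=S(=O)(C1CC1)N1CCc2nc(C#Cc3ccccc3)sc2C1` differs from compound 3 in one place: cyclopropylsulfonyl in place of (3-fluorocyclobutyl)carbonyl on an amine nitrogen in a ring. For the measured compounds named here, the steps that bear on this all alter the group on the same ring nitrogen: a 1.4-fold lower number from compound 1 to compound 2 (0.13 log units; within the scatter), a 1.3-fold lower number from compound 1 to compound 3 (0.11 log units; within the scatter) and a 1.0-fold higher number from compound 2 to compound 3 (0.02 log units; within the scatter). None of them exchanges a carbonyl for a sulfonyl, so the data give no direct guide to that exchange, and no step beyond the scatter is expected. Compound 4 is therefore estimated at 100 nM, with a range from 40 nM to 250 nM. This estimate amounts to an expected step of a 1.2-fold higher number from compound 3 to compound 4 (0.07 log units; within the scatter).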

Compound 4, half-maximal effective concentration: > 10000 nM
Compound 4: no number, only a limit; the forecaster's own chance of this, stated with the estimate: 5%; middle value at least 100-fold (2.00 log units) away from the limit.
By their numbers in this assay, from the lowest: compounds 2, 3 and 1 (each within the scatter of the next). At a limit, above all of these: compound 4.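

The earlier compounds shown here, with butyl, (3-methylcyclobutyl)carbonyl or (3-fluorocyclobutyl)carbonyl on the ring nitrogen, all lie within the scatter of one another, which made this position look forgiving. Cyclopropylsulfonyl shows that it is not, with an at least 110-fold higher number from compound 3 to compound 4 (2.07 log units; beyond the scatter), an at least 120-fold higher number from compound 2 to compound 4 (2.09 log units; beyond the scatter) and an at least 90-fold higher number from compound 1 to compound 4 (1.95 log units; beyond the scatter). In this assay compound 4 gives > 10000 nM, which is a limit of the assay and not a number.

Compound 4 exchanges both the carbonyl for a sulfonyl and the cyclobutyl ring for a cyclopropyl ring, so the compounds shown cannot say which of the two matters. A cyclopropylcarbonyl group on the same nitrogen would separate them.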